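Triazole substituent series: cyclopropyl to sulfonamide

The compounds below may be only part of what the source reports. "The series", "measured", "known", "first", "only" and "open" are said of these compounds alone.

Compound 3 `O=C1O[C@H]([C@@H](O)Cn2cc(C3CC3)nn2)C(OCc2ccccc2)=C1OCc1ccccc1` gives the highest number of the three measured in a functional assay on MCF7 cells (Homo sapiens) for antiproliferative activity, read by MTT assay, with a stated time of 72 h (on this read-out higher numbers stand for weaker inhibition and lower numbers for stronger inhibition), at 25900 nM. Compound 1 `O=C1O[C@H]([C@@H](O)Cn2cc(-c3ccc(Br)cc3)nn2)C(OCc2ccccc2)=C1OCc1ccccc1` gives 5620 nM and compound 2 `CCCCCc1ccc(-c2cn(C[C@H](O)[C@H]3OC(=O)C(OCc4ccccc4)=C3OCc3ccccc3)nn2)cc1` gives 9010 nM. The steps of a 4.6-fold higher number from compound 1 to compound 3 (0.66 log units; beyond the scatter) and a 2.9-fold higher number from compound 2 to compound 3 (0.46 log units; beyond the scatter) both end at compound 3, while a 1.6-fold higher number from compound 1 to compound 2 (0.20 log units; within the scatter) is within the scatter. Compound 4 `O=C1O[C@H]([C@@H](O)Cn2cc(CNS(=O)(=O)c3ccc(Cl)cc3)nn2)C(OCc2ccccc2)=C1OCc1ccccc1` carries the change ((((4-chlorophenyl)sulfonyl)amino)methyl in place of cyclopropyl on an aromatic carbon). Among the measured compounds shown here, the steps that bear on this change are the two into compound 3, each of which put cyclopropyl in place of an aryl group and raised the number by a modest amount; the change to compound 4 runs the other way and installs a larger group with a six-membered aromatic ring and a hydrogen-bond donor, which no measured compound holds. A modest fall in this assay is therefore expected, of about the size of those two steps reversed, with wide uncertainty. Compound 4 is estimated at 8000 nM, in the range 3000 nM to 22000 nM. That estimate means an expected step of a 3.2-fold lower number from compound 3 to compound 4 (0.51 log units; beyond the scatter).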

Compound 4, half-maximal inhibitory concentration: 4170 nM
Estimate against measurement, compound 4: 1.9-fold (0.28 log units) above; measured number inside the range.
By their numbers in this assay, from the lowest: compounds 4, 1 and 2 (each within the scatter of the next, the first and the last beyond it); then compound 3.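

At this aromatic carbon, a six-membered aromatic ring need not be attached directly: in this assay the (((4-chlorophenyl)sulfonyl)amino)methyl group gives a 6.2-fold lower number from compound 3 to compound 4 (0.79 log units; beyond the scatter). The same group also gives a 2.2-fold lower number from compound 2 to compound 4 (0.33 log units; beyond the scatter), while a 1.3-fold lower number from compound 1 to compound 4 (0.13 log units; within the scatter) is within the scatter, so it cannot be separated from the 4-bromophenyl group. Among these four compounds, a group with a hydrogen-bond donor is compatible with a number as low as any measured, and all three groups bearing a six-membered aromatic ring give lower numbers than cyclopropyl.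

As far as these compounds go, it remains open whether the chlorine, the sulfonyl or the amino hydrogen carries the step, and how an amine, a carboxylic acid or a longer chain would read at this carbon. No measurement here speaks to what lies behind these steps.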